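Swapping One Bicyclic Group for Another in a Small Series

A few compounds are considered here, and "the series" means these few. Any claim that something is new, unique, unknown or untested is made for them only; others in the source may bear on it.

Compound 1 `O=C1O/C(=C\Cn2cnc3cncc(Br)c32)C(OCc2ccccc2)=C1OCc1ccccc1` gives 46900 nM in a functional assay on HepG2 cells (Homo sapiens) for antiproliferative activity, read by MTT assay, with a stated time of 72 h; a lower number here means a stronger inhibitor, a higher number a weaker inhibitor.
Compound 2 `O=C1NC(O)(CCn2cnc3cncc(Br)c32)C(OCc2ccccc2)=C1OCc1ccccc1` gives 66500 nM in this assay.
Compound 3 `O=C1NC(O)(CCn2cnc3ccnc(Cl)c32)C(OCc2ccccc2)=C1OCc1ccccc1` reaches only the limit of > 100000 nM in this assay, so no number is known for it.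

Compound 1 and compound 2 share the same pair of benzyloxy substituents and the same bicyclic group on the chain, but the difference between their two cores is not broken down here. Their two values in this assay sit within the scatter of each other, so nothing can be said about an order between them.

From compound 2 to compound 3 the change is a group of 10 heavy atoms (6 carbon, 3 nitrogen, 1 chlorine; one five-membered aromatic ring with 2 hetero atoms, one six-membered aromatic ring with 1 hetero atom) in place of a group of 10 heavy atoms (6 carbon, 3 nitrogen, 1 bromine; one five-membered aromatic ring with 2 hetero atoms, one six-membered aromatic ring with 1 hetero atom), on a saturated chain carbon, two bonds along the chain from a saturated ring carbon. This gives an at least 1.5-fold higher number from compound 2 to compound 3 (0.17 log units; that floor lies within the scatter), and the floor of that step comes from the limit of > 100000 nM in this assay, at which 1 of the 3 values shown sits, so the true step may be larger than the floor.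

Compound 4 `O=C1O/C(=C\Cn2cnc3ccnc(Cl)c32)C(OCc2ccccc2)=C1OCc1ccccc1` is not yet measured. It arises from compound 1 by a group of 10 heavy atoms (6 carbon, 3 nitrogen, 1 chlorine; one five-membered aromatic ring with 2 hetero atoms, one six-membered aromatic ring with 1 hetero atom) in place of a group of 10 heavy atoms (6 carbon, 3 nitrogen, 1 bromine; one five-membered aromatic ring with 2 hetero atoms, one six-membered aromatic ring with 1 hetero atom), on a saturated chain carbon bound to a double-bonded chain carbon. This is the same kind of change as that from compound 2 to compound 3, but not the same: in compound 4 the group sits on a saturated chain carbon bound to a double-bonded chain carbon, whereas in compound 3 it sits on a saturated chain carbon, two bonds along the chain from a saturated ring carbon. Compound 4 is expected to show a 2.0-fold higher number from compound 1 to compound 4 (0.31 log units; beyond the scatter), a step resting on an at least 1.5-fold higher number from compound 2 to compound 3 (0.17 log units; that floor lies within the scatter) together with the position of compound 1 at 46900 nM. For compound 4 the estimate in this assay is 95000 nM, with an expected range from 45000 nM to 250000 nM.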

Compound 4, half-maximal inhibitory concentration: > 100000 nM
Compound 4: no number, only a limit (the forecaster's own chance of this, stated with the estimate: 45%); at least 1.0-fold (0.02 log units) between middle value and limit.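

In this assay, carrying the change to the core of compound 1 gives an at least 2.1-fold higher number from compound 1 to compound 4 (0.32 log units; beyond the scatter). On this core, then, the exchange of the bromine-containing group for the chlorine-containing group gives a step whose floor already clears the scatter, whereas the floor on the other core does not, and neither step has a known full size: the limit of > 100000 nM in this assay, at which 2 of the 4 values shown sit. This shows that the change leads to higher numbers on the core of compound 1 and does not contradict what was seen on the core of compound 2, but it does not show that the change has the same size on both cores: the same change on two cores in this assay, an at least 1.5-fold higher number (0.17 log units; that floor lies within the scatter) from compound 2 to compound 3 and an at least 2.1-fold higher number (0.32 log units; beyond the scatter) from compound 1 to compound 4; the limit leaves it open whether they differ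

The compounds shown leave open what either core would give with a group in that place carrying neither bromine nor chlorine, such as a fluorine-bearing or amine-bearing bicyclic group, and whether a group of that kind would bring a measurable number where the chlorine-containing group gives only a limit. They also leave open how a longer chain to the bicyclic group, or methoxy or free hydroxyl groups in place of the two benzyloxy substituents, would read in this assay.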